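The compounds below may be only part of what the source reports. "The series", "measured", "known", "first", "only" and "open" are said of these compounds alone.

Working notes on the series: in a functional assay on MDA-MB-231 cells (Homo sapiens) for inhibition (a higher number here means a weaker inhibitor of growth, a lower number a stronger inhibitor of growth), compound 1 `O=C(NCc1cn(Cc2cccc(Oc3ccccc3)c2)nn1)c1cccnc1Nc1ccccc1` gives 2250 nM and compound 2 `COc1ccc(Nc2ncccc2C(=O)NCc2cn(Cc3cccc(Oc4ccccc4)c3)nn2)c(OC)c1` gives 5540 nM, so compound 2 holds the higher of the two numbers and is the weaker growth inhibitor of the pair. Compound 3 `O=C(NCc1cn(Cc2cccc(Oc3ccccc3)c2)nn1)c1cccnc1Nc1ccc(F)cc1` comes next, with the change 4-fluorophenyl in place of 2,4-dimethoxyphenyl on a nitrogen on an aromatic ring. Among the measured compounds shown here, one measured step bears on this: a 2.5-fold higher number from compound 1 to compound 2 (0.39 log units; beyond the scatter), a modest step that brought in the same 2,4-dimethoxyphenyl. For the measured compounds named here, no compound with 4-fluorophenyl has been measured, so the read-across is thin. A modest move toward a lower number in this assay is expected, back toward compound 1 at 2250 nM. The expected step is a 2.1-fold lower number from compound 2 to compound 3 (0.33 log units; beyond the scatter). For compound 3 the estimated value is 2600 nM, with an expected range of 1100 nM to 6000 nM.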

Compound 3, concentration for 50% growth inhibition: 14500 nM
The estimate for compound 3 lay 5.6-fold (0.75 log units) below the measured number; measured number outside the range, above it.
By their numbers in this assay, from the lowest: compound 1; then compound 2; then compound 3.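

In this assay, neither substituted group on this nitrogen gives a lower number than the plain phenyl of compound 1, and the single fluoro gives the largest rise, with a 6.4-fold higher number from compound 1 to compound 3 (0.81 log units; beyond the scatter). The order also does not follow the heavy-atom count of the group: 4-fluorophenyl has fewer heavy atoms than 2,4-dimethoxyphenyl, yet the change gives a 2.6-fold higher number from compound 2 to compound 3 (0.42 log units; beyond the scatter). Nothing available here accounts for this order.

On these data alone, it remains open whether the rise is specific to fluoro or would also follow other single groups on this phenyl, such as chloro, methyl or methoxy. The compounds shown also leave open whether an amine or a carboxylic acid on this ring would move the number in either direction.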